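Amino in place of chloro on a purine alkylator

The source may hold more compounds than are shown below. What is called first, only, known or untested is meant among the compounds shown, and "the series" means these compounds.

Compound 1 `ClCc1ccccc1Cn1cnc2c(Cl)nc(Cl)nc21`: 6760 nM
Compound 2 `ClCc1cccc(Cn2cnc3ncnc(Cl)c32)c1`: > 100000 nM (a limit of the assay)
Compound 3 `ClCc1cccc(Cn2cnc3c(Cl)nc(Cl)nc32)c1`: 17000 nM

In a functional assay on NCI-H522 cells (Homo sapiens) for cytotoxicity, read by sulforhodamine B assay, with a stated time of 48 h (a lower number here means that less compound is tolerated, a higher number that more compound is tolerated), compound 1 gives 6760 nM, the lowest of the two numbers. The nearest is compound 3 with 17000 nM, a gap that lies beyond the usual scatter. Compound 2 reaches only the limit (the limit of > 100000 nM in this assay, at which 1 of the 3 values shown sits), so no number is known for it. For the measured compounds named here, compound 3 carries two chloro groups on the shared core and gives a number, while compound 2 carries one and gives only a limit; no step between them is defined, so their two values are all that can be said.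

Compound 4 `Nc1nc(Cl)c2ncn(Cc3ccccc3CCl)c2n1` arises from compound 1 by the change (amino in place of chloro on an aromatic carbon). Going by the values given here, no measured pair shows this exchange, and the values of compound 2 and compound 3 suggest that the core with fewer chloro groups tolerates more compound. Compound 4 is therefore expected to show a moderately higher value, estimated at 30000 nM, within 8000 nM to 100000 nM. The step of a 4.4-fold higher number from compound 1 to compound 4 (0.65 log units; beyond the scatter) is expected to exceed the scatter, toward more compound tolerated.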

Compound 4, concentration lethal to 50% of the cells: > 100000 nM
Compound 4: no number, only a limit; the forecaster's own chance of this, stated with the estimate: 25%; middle value at least 3.3-fold (0.52 log units) from the limit.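

In this assay, for the compounds shown here, amino in place of chloro on the aromatic carbon between two ring nitrogen atoms gives an at least 14-fold higher number from compound 1 to compound 4 (1.17 log units; beyond the scatter), the first change at a single position of the shared core that can be read here. Going by these compounds, compound 4 gives > 100000 nM, which is a limit of the assay, so the step has only a lower bound and its full size stays unknown. Compound 4 thus joins compound 2 at the end of the range that the assay reports: the limit of > 100000 nM in this assay, at which 2 of the 4 values shown sit.

The compounds shown leave open whether a methoxy or a methylamino group at this position would give a like step. They also leave open whether the same exchange would give a like step on compound 3, whose chloromethyl group sits elsewhere.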